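Pyridin-2-yl for 4-Fluorophenyl on a Benzyl Ether Antagonist

The compounds below may be only part of what the source reports. "The series", "measured", "known", "first", "only" and "open" are said of these compounds alone.

Compound 1 `Cc1oc2ccc(NC(=O)COc3ccc(OC(F)(F)F)cc3)cc2c1C` gives > 1000 nM in an assay on CHO cells for displacement of a labelled ligand from melanin-concentrating hormone receptor 1 (Homo sapiens), read by scintillation counting, with a stated time of 1 h (on this read-out lower numbers stand for stronger inhibition and higher numbers for weaker inhibition), a limit of the assay and not a number.
Compound 2 `Cc1c(C2CC2)nc2ccc(-n3ccc(OCc4ccc(F)cc4)cc3=O)cn12` gives 47 nM in this assay.
Compound 3 `Cc1c(CO)nc2ccc(-n3ccc(OCc4ccc(F)cc4)cc3=O)cn12` gives > 1000 nM in this assay, again a limit and not a number.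

Within the data shown here, compound 2 is the only compound of the three with a measured number; the other two sit at the limit of > 1000 nM in this assay, at which 2 of the 3 values shown sit. Among the measured compounds shown here, the one step that can be read, an at least 21-fold higher number from compound 2 to compound 3 (1.32 log units; beyond the scatter), concerns a change on the core, not the ether side chain.

Compound 4 `Cc1c(C2CC2)nc2ccc(-n3ccc(OCc4ccccn4)cc3=O)cn12` differs from compound 2 by pyridin-2-yl in place of 4-fluorophenyl on a saturated chain carbon bound to an oxygen on an aromatic ring. For the measured compounds named here, no measured step touches this place, so the expectation rests on the general observation that compound 2 is the only compound here to show a number at all. A moderate weakening is expected for compound 4, giving an estimated step of a 3.2-fold higher number from compound 2 to compound 4 (0.50 log units; beyond the scatter) in this assay. Compound 4 is therefore estimated at 150 nM, with a range from 40 nM to 600 nM.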

Compound 4, half-maximal inhibitory concentration: 240 nM
For compound 4 the middle estimate is 1.6-fold (0.20 log units) below the measured one; measured number inside the range.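

Among these compounds, the earlier step concerned the core, so this is the first measured change on the ether side chain, and in this assay it reads as a 5.1-fold higher number from compound 2 to compound 4 (0.71 log units; beyond the scatter). The cost of replacing 4-fluorophenyl with pyridin-2-yl at this place is therefore modest, and a ring with one hetero atom and one counted hydrogen-bond acceptor is accepted here without losing a measurable inhibition. Compound 4 joins compound 2 as the second compound with a real number, and so stays clear of the limit: the limit of > 1000 nM in this assay, at which 2 of the 4 values shown sit.

The change removes the fluorine and brings in the ring nitrogen in a single step, so the compounds shown cannot say which of the two carries the loss, and plain phenyl, pyridin-3-yl or pyridin-4-yl at the same place would be needed to separate them. Also open, from the compounds shown here alone, is how a longer chain carrying the pyridin-2-yl, in place of the single saturated chain carbon, would read in this assay.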